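This account rests on a few compounds, and the source may have more. Where it says the series, first, only, none or still open, it means among the compounds named here.

Measured so far in a functional assay on A549 cells (Homo sapiens) for cytotoxicity, read by sulforhodamine B assay, with a stated time of 48 h; on this read-out higher numbers stand for lower toxicity in this test and lower numbers for higher toxicity in this test:
Compound 1 `Nc1nc(Cl)c2ncn(Cc3ccc(CCl)cc3)c2n1` reports a limit, > 100000 nM.
Compound 2 `ClCc1cccc(Cn2cnc3c(Cl)nc(Cl)nc32)c1` gives 52500 nM.
Compound 3 `ClCc1ccc(Cn2cnc3c(Cl)nc(Cl)nc32)cc1` gives 74100 nM.

Compound 2 and compound 3 share the same atoms joined differently; the difference between the two cores is not broken down here, and their two values lie within the usual scatter of each other. From compound 3 to compound 1 the change is amino in place of chloro on an aromatic carbon, and it brought an at least 1.3-fold higher number from compound 3 to compound 1 (0.13 log units; that floor lies within the scatter), with compound 1 sitting at the limit of > 100000 nM in this assay, at which 1 of the 3 values shown sits.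

Compound 4 `Nc1nc(Cl)c2ncn(Cc3cccc(CCl)c3)c2n1` is not yet measured. It differs from compound 2 by amino in place of chloro on an aromatic carbon, the same kind of change, and the two place descriptions agree word for word.

Resting on the step from compound 3 to compound 1 an at least 1.3-fold higher number from compound 3 to compound 1 (0.13 log units; that floor lies within the scatter), a step of a 1.9-fold higher number from compound 2 to compound 4 (0.28 log units; within the scatter) is expected from compound 2 to compound 4, in this assay. Compound 4 is therefore estimated at 100000 nM, between 45000 nM and 250000 nM.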

Compound 4, concentration lethal to 50% of the cells: 63100 nM
Estimate against measurement, compound 4: 1.6-fold (0.20 log units) above; the range from low to high includes it.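

In this assay, putting amino in place of chloro on the aromatic carbon between two ring nitrogen atoms gave a 1.2-fold higher number from compound 2 to compound 4 (0.08 log units; within the scatter), so on this core the change left no mark that can be told apart from repeat-measurement noise. Set beside the same change on the other core, the result stays undecided: the same change on two cores in this assay, an at least 1.3-fold higher number (0.13 log units; that floor lies within the scatter) from compound 3 to compound 1 and a 1.2-fold higher number (0.08 log units; within the scatter) from compound 2 to compound 4; the limit leaves it open whether they differ Compound 1 carries a limit rather than a number, so the two steps cannot be compared in size, and nothing here shows that the change behaves alike on both cores.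

The compounds shown leave open whether a different group on that same carbon, such as a methoxy group or a methylamino group, would move the number beyond the usual scatter.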